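The source may report more compounds than this note shows. Statements on the series, on what has been measured and on what is new or still open speak of the compounds shown alone.

Measured so far:
Compound 1 `Cc1ccc(Nc2ncc(C(F)(F)F)c(N3Cc4cccc(N(C)S(C)(=O)=O)c4C3)n2)cc1C`: > 30000 nM, a limit of the assay
Compound 2 `COc1cc(N2CCN(C(C)=O)CC2)ccc1Nc1ncc(C(F)(F)F)c(N2Cc3cccc(N(C)S(C)(=O)=O)c3C2)n1`: 1300 nM

In a functional assay on HeLa cells (Homo sapiens) for antiproliferative activity, read by spectrophotometry, with a stated time of 2 days (a higher number here means a weaker inhibitor of growth, a lower number a stronger inhibitor of growth), compound 2 gives a numerical value of 1300 nM. Compound 1 gives no number, only a limit, and the record for compound 1 is the limit of > 30000 nM in this assay, at which 1 of the 2 values shown sits.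

Compound 3 `Cc1cc(F)ccc1Nc1ncc(C(F)(F)F)c(N2Cc3cccc(N(C)S(C)(=O)=O)c3C2)n1` has not yet been measured. It keeps the core of compound 1 and changes one group, with 4-fluoro-2-methylphenyl in place of 3,4-dimethylphenyl on a nitrogen on an aromatic ring. For the measured compounds named here, no measured pair tests this change, so the expectation has little to rest on.

In this assay, no large gain is expected: compound 3 should stay a weak inhibitor of growth, close to the limit or at it, with at best a small move toward stronger inhibition. This expectation rests on compound 1, whose value of > 30000 nM is a limit. The expected step is an at least 1.2-fold lower number from compound 1 to compound 3 (0.07 log units; that floor lies within the scatter). For compound 3 the estimate is 25000 nM, with an expected range of 7000 nM to 50000 nM.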

Compound 3, concentration for 50% growth inhibition: 6500 nM
Beside the measured number, compound 3's estimate is 3.8-fold (0.59 log units) above it, and the stated range ends above it.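

In this assay, exchanging 3,4-dimethylphenyl for 4-fluoro-2-methylphenyl gives an at least 4.6-fold lower number from compound 1 to compound 3 (0.66 log units; beyond the scatter). This shows that the antiproliferative read-out responds to the aryl group at this position even when the rest of the structure stays fixed, and that the two groups need not differ in size or in their counts of hydrogen-bond donors and hydrogen-bond acceptors for this to happen: each has 8 heavy atoms, with 0 hydrogen-bond donors and 0 hydrogen-bond acceptors. Compound 1 gives only a limit, so the step has a floor and its full size remains unknown: the limit of > 30000 nM in this assay, at which 1 of the 3 values shown sits.

The compounds shown leave open whether the 4-fluoro part, the 2-methyl part or the two together account for the step, a question that a phenyl group carrying only the fluorine or only the methyl would address. They also leave open how the value would respond to a quite different substituent on this aryl ring, such as an amine or a carboxylic acid.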